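Boc-piperazine versus methylpiperazine on a pyrazoline amide

The source may report more compounds than this note shows. Statements on the series, on what has been measured and on what is new or still open speak of the compounds shown alone.

Of the compounds shown here, two sharing a common core have been measured in a functional assay on PC-3 cells (Homo sapiens) for cytotoxicity, read by MTT assay, with a stated time of 48 h; a lower number here means a stronger inhibitor, a higher number a weaker inhibitor. Compound 1 `CCN(CC)CC(=O)N1N=C(C)CC1c1ccccc1O` carries a diethylamino group and gives 25900 nM. Compound 2 `CC1=NN(C(=O)CN2CCN(C(=O)OC(C)(C)C)CC2)C(c2ccccc2O)C1` carries a tert-butoxycarbonyl-protected piperazine and gives 3440 nM, the lower of the two numbers and beyond the scatter from compound 1. Compound 3 `CC1=NN(C(=O)CN2CCN(C)CC2)C(c2ccccc2O)C1` has not yet been measured; it differs from compound 2 by methyl in place of tert-butoxycarbonyl on an amine nitrogen in a ring. Among the compounds with values here, no measured pair isolates this change, so its effect is unknown; the nearest guidance is that compound 1, whose side chain is also a small tertiary amine, gives 25900 nM, which is the weaker of the two. Compound 3 is therefore expected to be a weaker inhibitor than compound 2, the estimated step from a 2.9-fold higher number from compound 2 to compound 3 (0.46 log units; beyond the scatter). The estimated value for compound 3 is 10000 nM, with a range from 3000 nM to 35000 nM.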

Compound 3, half-maximal inhibitory concentration: 11800 nM
The estimate for compound 3 lay 1.2-fold (0.07 log units) below the measured number; low and high end bracket the measured number.
By their numbers in this assay, from the lowest: compound 2; then compound 3; then compound 1.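

In this assay, within the data shown here, methyl in place of tert-butoxycarbonyl on the amine nitrogen in the ring gives a 3.4-fold higher number from compound 2 to compound 3 (0.54 log units; beyond the scatter), the first pair to isolate this position, and it shows that the group on this nitrogen alters the number even with the rest of the structure held constant. A second single change, 4-methylpiperazin-1-yl in place of diethylamino on a saturated chain carbon bound to a carbonyl carbon, gives a 2.2-fold lower number from compound 1 to compound 3 (0.34 log units; beyond the scatter), so the amine on the side chain also counts when the nitrogen carries only methyl. No measurement at hand explains either step.

The compounds shown leave open whether a ring nitrogen bearing only hydrogen, or an acetyl group there, would stand nearer to methyl or to tert-butoxycarbonyl. They also leave open whether the lower number follows the carbonyl of tert-butoxycarbonyl or its tert-butyl part.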